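Removing one methyl from compound 1

This account rests on a few compounds, and the source may have more. Where it says the series, first, only, none or still open, it means among the compounds named here.

Compound 1 `CC(C)[C@H](N)C(=O)N[C@@H](CCC(=O)C=[N+]=[N-])C(=O)OCc1c[nH]c2ccccc12` sits in the middle of three measured compounds. In an ADME assay on a cell-free system (plasma, Homo sapiens) for metabolic stability, read by LC-MS, with a stated time of 60 min, tested at 10 uM (a lower number here means that less of the compound is left, a higher number that more of the compound is left), compound 1 gives 30%. Compound 3 `CCOC(=O)[C@H](CCC(=O)C=[N+]=[N-])NC(=O)[C@@H](N)CC(C)C` gives a lower 1%, and compound 2 `COC(=O)[C@H](CCC(=O)C=[N+]=[N-])NC(=O)OC(OC(=O)C(C)(C)C)C(C)C` gives a higher 91%. Both gaps lie beyond the usual scatter of repeated measurements. Among the compounds with values here, these three compounds differ from one another in more than one place, so no measured pair shows the effect of a single small edit.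

Compound 4 `CC[C@H](N)C(=O)N[C@@H](CCC(=O)C=[N+]=[N-])C(=O)OCc1c[nH]c2ccccc12` differs from compound 1 by just such an edit: hydrogen in place of methyl on a saturated chain carbon bound to two saturated chain carbons. It puts hydrogen in place of methyl on a saturated chain carbon bound to two saturated chain carbons, which turns isopropyl into ethyl.

Within the data shown here, with no direct precedent, the evidence for what follows is thin. Like compound 1, compound 3 has a free amino group, and compound 3 keeps only 1%, so very low numbers do occur among such compounds. A downward move of modest size in this assay therefore seems the likelier outcome, and the expected change is a number 12 percentage points lower from compound 1 to compound 4 (beyond the scatter). Compound 4 is estimated at 18%, with an expected range of 4% to 38%.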

Compound 4, percent of the compound remaining: 12%
Beside the measured number, compound 4's estimate is 6 percentage points above it; measured number inside the range.
By their numbers in this assay, from the lowest: compound 3; then compound 4; then compound 1; then compound 2.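

In this assay, within the data shown here, hydrogen in place of methyl on a saturated chain carbon bound to two saturated chain carbons gives a number 18 percentage points lower from compound 1 to compound 4 (beyond the scatter), the first measured step in this set that comes from a single small edit. This place on the molecule therefore matters: with the rest of compound 1 unchanged, shortening isopropyl to ethyl, a loss of just one carbon, is enough to leave measurably less of the compound at the end of the test. Nothing at hand explains why the number moves in this direction, so the step stands as an observation only.

Only one replacement at this place is shown, so it remains open whether a larger group such as tert-butyl would leave more of the compound than isopropyl does, or whether a smaller one such as methyl would leave still less. On these data alone, it is also open whether turning isopropyl into ethyl would give a step of similar size and direction with a methyl ester or an ethyl ester in place of the ester carried by compound 1.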